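Benzoxaborole chalcones: amino for ethyl on the aryl ketone

The compounds below may be only part of what the source reports. "The series", "measured", "known", "first", "only" and "open" are said of these compounds alone.

Going by the values given here, compound 2 `CCc1ccc(C(=O)/C=C/c2ccc3c(c2)B(O)OC3)cc1` is the one compound of the pair that gives a number in a toxicity assay on MCF-10A cells (Homo sapiens) for cytotoxicity, read by MTT assay, with a stated time of 48 h (a lower number here means a stronger inhibitor, a higher number a weaker inhibitor), where compound 2 gives 8800 nM. Compound 1 `Cn1cccc1C(=O)/C=C/c1ccc2c(c1)B(O)OC2` gives in this assay > 100000 nM, which is a limit of the assay and not a number; this is the line (the limit of > 100000 nM in this assay, at which 1 of the 2 values shown sits), so compound 2 stands alone as the measured point. Compound 3 `Nc1ccc(C(=O)/C=C/c2ccc3c(c2)B(O)OC3)cc1` has not been run in this assay. Compound 3 differs from compound 2 by amino in place of ethyl on an aromatic carbon. Among the compounds with values here, no step between measured compounds is available to scale this change. The expectation is a modest weakening, a step of a 2.3-fold higher number from compound 2 to compound 3 (0.36 log units; beyond the scatter), which may not rise beyond the scatter. Compound 3 is estimated to give 20000 nM in this assay, within 5000 nM to 100000 nM.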

Compound 3, half-maximal inhibitory concentration: 19900 nM
Compound 3: the middle estimate sits 1.0-fold (0.00 log units) above what was measured, within the range that was stated.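

Amino in place of ethyl, on the aromatic carbon para to a large group, now has a measured size: in this assay the change gives a 2.3-fold higher number from compound 2 to compound 3 (0.35 log units; beyond the scatter), so the number stays measurable with the smaller amino group at this place. Replacing 1-methyl-1H-pyrrol-2-yl on the carbonyl carbon with 4-aminophenyl gives an at least 5.0-fold lower number from compound 1 to compound 3 (0.70 log units; beyond the scatter), so a para-substituted aryl ketone is separated from the pyrrole compound even with amino in place of ethyl. That step is only a bound, as compound 1 gives a limit of the assay and not a number: the limit of > 100000 nM in this assay, at which 1 of the 3 values shown sits.

Still open, from the compounds shown here alone, is whether the step follows from the amino group entering or from the ethyl group leaving, which a methyl, a methoxy or a dimethylamino group at this place could separate. A longer chain such as propyl would show whether the number keeps falling beyond ethyl.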